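The source may report more compounds than this note shows. Statements on the series, on what has been measured and on what is new or still open speak of the compounds shown alone.

Compound 1 `CCN(CC)CCNC(=O)c1cc(C(CC)(CC)c2ccc(C#CC(O)(CC)CC)c(C)c2)cn1CC` gives in an assay on cells for agonist activity at vitamin D3 receptor (Homo sapiens), read by microscopy (on this read-out lower numbers stand for an effect already at smaller amounts and higher numbers for an effect only at larger amounts of compound), a value of 6.98 nM. Compound 2 `CCn1cc(C(CC)(CC)c2ccc(C#CC(O)(CC)CC)c(C)c2)cc1C(=O)OCCO` gives 12.6 nM. Compound 3 `CCCCC(=O)c1cc(C(CC)(CC)c2ccc(C#CC(O)(CC)CC)c(C)c2)cn1CC` gives > 50 nM, which is a limit of the assay rather than a number.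

Compound 3 therefore stands at the edge of what was measured, (the limit of > 50 nM in this assay, at which 1 of the 3 values shown sits). Compound 4 `CCn1cc(C(CC)(CC)c2ccc(C#CC(O)(CC)CC)c(C)c2)cc1C(=O)NCCC(=O)O` differs from compound 3 in one place: (2-carboxyethyl)amino in place of butyl on a carbonyl carbon. Among the compounds with values here, two measured steps bear on this, both running in the opposite direction: an at least 7.1-fold higher number from compound 1 to compound 3 (0.85 log units; beyond the scatter) and an at least 3.9-fold higher number from compound 2 to compound 3 (0.59 log units; beyond the scatter). Compound 4 puts an amino group back on the carbonyl carbon, as compound 1 has, so a lower number is expected in this assay, roughly an at least 4.1-fold lower number from compound 3 to compound 4 (0.61 log units; beyond the scatter). Compound 4 is estimated at about 12 nM, within 4 nM to 35 nM.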

Compound 4, half-maximal effective concentration: > 50 nM
Compound 4: no number, only a limit (the forecaster's own chance of this, stated with the estimate: 10%); middle value at least 4.1-fold (0.61 log units) away from the limit.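

Bringing back an amide nitrogen on the carbonyl carbon does not by itself restore a low number: in this assay, carboxy in place of diethylamino at the chain end gives an at least 7.1-fold higher number from compound 1 to compound 4 (0.85 log units; beyond the scatter). Against the 2-hydroxyethoxy ester, (2-carboxyethyl)amino gives an at least 3.9-fold higher number from compound 2 to compound 4 (0.59 log units; beyond the scatter). Compound 4, like compound 3, gives only a limit of the assay, so the step between them cannot be read: the limit of > 50 nM in this assay, at which 2 of the 4 values shown sit.

Still open, going by these compounds, is whether a methyl ester in place of the carboxylic acid on this chain would give a measurable number. A chain ending in a primary amine or a hydroxyl group poses the same question.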